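A few compounds are considered here, and "the series" means these few. Any claim that something is new, unique, unknown or untested is made for them only; others in the source may bear on it.

Measured in an assay on CHO cells for displacement of a labelled ligand from Free fatty acid receptor 1 (Rattus norvegicus), read by scintillation counting, with a stated time of 90 min, in the presence of a further agent that is not named here; a higher number here means a weaker inhibitor, a lower number a stronger inhibitor:
- compound 1 `Cc1cccc(C)c1-c1cccc(COc2ccc(CCC(=O)O)c(F)c2)c1` gives 36 nM
- compound 3 `COc1ccc(COc2ccc(CCC(=O)O)cc2)cc1-c1c(C)cccc1C` gives 87 nM
- compound 2 `COc1ccc(-c2c(C)cccc2C)cc1COc1ccc(CCC(=O)O)cc1` gives 10000 nM

Compound 1 carries the lowest number of the three. Compound 3 stands next, its number higher than that of compound 1 by a margin beyond the scatter, and compound 2 lies far above both. Compound 4 `CCOCCOc1cc(C)c(-c2cccc(COc3ccc(CCC(=O)O)c(F)c3)c2)c(C)c1` is not yet measured. It differs from compound 1 in one place: 2-ethoxyethoxy in place of hydrogen on an aromatic carbon. Within the data shown here, no measured pair shows this change, so no step can be read from the data; the expectation is a small step toward a lower number, or none beyond the scatter. Compound 4 is expected at 20 nM, range 6 nM to 80 nM. The expected step is a 1.8-fold lower number from compound 1 to compound 4 (0.26 log units; within the scatter).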

Compound 4, inhibition constant: 4.5 nM
Compound 4: the middle estimate sits 4.4-fold (0.65 log units) above what was measured; the whole stated range lies above it.
By their numbers in this assay, from the lowest: compound 4; then compound 1; then compound 3; then compound 2.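

In this assay the aromatic carbon meta to two methyl groups and para to a large group accepts a substituent: 2-ethoxyethoxy in place of hydrogen gives an 8.0-fold lower number from compound 1 to compound 4 (0.90 log units; beyond the scatter) and this lies beyond the scatter. Among these compounds, the earlier compounds all carry hydrogen there, so this single pair is the first reading of the position. Nothing measured here bears on the reason for the step.

On these data alone, whether a hydroxyl, a shorter ethoxy or a chain ending in an amine would give a similar step remains open. So does whether the step carries over to the core of compound 3.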